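Two chlorobenzyl regioisomers on a shared core, before measurement

The compounds below may be only part of what the source reports. "The series", "measured", "known", "first", "only" and "open" are said of these compounds alone.

Measured compounds:
- compound 1, `COc1ccc(/C=C2\CN(Cc3cn(Cc4cccc(Cl)c4)nn3)C/C(=C\c3ccc(OC)cc3)C2=O)cc1`: 32500 nM
- compound 3, `COc1ccc(/C=C2\CN(Cc3cn(Cc4ccccc4Cl)nn3)C/C(=C\c3ccc(OC)cc3)C2=O)cc1`: 36300 nM
- compound 2, `COc1ccc(/C=C2\CN(C(=S)SCc3cn(Cc4cccc(Cl)c4)nn3)C/C(=C\c3ccc(OC)cc3)C2=O)cc1`: its result is only a limit of the assay, > 80000 nM

All values come from a functional assay on PC-3 cells (Homo sapiens) for cytotoxicity, read by MTT assay, with a stated time of 24 h; on this read-out lower numbers stand for stronger inhibition and higher numbers for weaker inhibition. Compound 1 and compound 3 share a core, and compound 2 carries a different core; how the two cores differ is not broken down here. From compound 1 to compound 3 the change is 2-chlorophenyl in place of 3-chlorophenyl on a saturated chain carbon bound to an aromatic nitrogen, and the step it made, a 1.1-fold higher number from compound 1 to compound 3 (0.05 log units; within the scatter), is within the scatter. Compound 4, `COc1ccc(/C=C2\CN(C(=S)SCc3cn(Cc4ccccc4Cl)nn3)C/C(=C\c3ccc(OC)cc3)C2=O)cc1`, is not yet measured in this assay. It differs from compound 2 by the same change, (2-chlorophenyl in place of 3-chlorophenyl on a saturated chain carbon bound to an aromatic nitrogen), at the same place. Compound 2 sits at the limit of > 80000 nM in this assay, at which 1 of the 3 values shown sits, so the starting point for compound 4 is itself only a limit. Because a 1.1-fold higher number from compound 1 to compound 3 (0.05 log units; within the scatter) shows this swap leaving the value essentially unchanged on the other core, compound 4 is expected to stay near the limit as well, with an expected step that the limit leaves unreadable from compound 2 to compound 4. The estimate for compound 4 is 100000 nM, within 50000 nM to 200000 nM.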

Compound 4, half-maximal inhibitory concentration: 60100 nM
The estimate for compound 4 lay 1.7-fold (0.22 log units) above the measured number; the measured number falls inside the stated range.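

Compound 2 has only a limit of the assay in this assay, not a measured number: the limit of > 80000 nM in this assay, at which 1 of the 4 values shown sits.

On the core of compound 2, swapping 3-chlorobenzyl for 2-chlorobenzyl gives an at least 1.3-fold lower number from compound 2 to compound 4 (0.12 log units; that floor lies within the scatter), so a real shift is neither shown nor ruled out. The comparison with the shared core of compound 1 and compound 3 therefore shows neither that the change carries over unaltered nor that it behaves differently on the two cores: the same change on two cores in this assay, a 1.1-fold higher number (0.05 log units; within the scatter) from compound 1 to compound 3 and an at least 1.3-fold lower number (0.12 log units; that floor lies within the scatter) from compound 2 to compound 4; the limit leaves it open whether they differ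

A firm number for compound 2 would be needed to settle how large the step on its core really is. The compounds shown also leave open how the value in this assay would respond on either core if the chlorobenzyl group gave way to a plain benzyl or a longer alkyl chain.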